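Swapping a hydroxy for a methyl on a weak antiproliferative

This account rests on a few compounds, and the source may have more. Where it says the series, first, only, none or still open, it means among the compounds named here.

Of the compounds shown here, three have been tested in a functional assay on MCF7 cells (Homo sapiens) for antiproliferative activity, read by MTT assay, with a stated time of 72 h (on this read-out higher numbers stand for weaker inhibition of growth and lower numbers for stronger inhibition of growth), so far. Compound 1 `Clc1ccc(Nc2nc3ncccc3n2Cc2ccccc2)cc1` gives 48000 nM in this assay. Compound 2 `Cc1ccc(Nc2nc3ncccc3n2Cc2ccccc2)cc1[N+](=O)[O-]` gives 27800 nM there. Compound 3 `Cn1nc(-c2ccnc(Nc3cccc(O)c3)n2)c2ccccc21`, built on a different core from the first two, gives 28200 nM in the same test. The number for compound 3 sits next to that of compound 2, the two differing only within the usual scatter of repeated measurements, and its distance to compound 1 also stays within that scatter, so the three values cannot be ranked against one another with any confidence.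

Compound 4 `Cc1cccc(Nc2nccc(-c3nn(C)c4ccccc34)n2)c1` differs from compound 3 in one place: methyl in place of hydroxy on an aromatic carbon. Within the data shown here, no pair of measured compounds shows this same change, so there is no measured step to lean on. The set gives no hint that a change this small, on a ring carbon, moves the number far. The expectation for compound 4 is therefore a step from compound 3 of about a 1.2-fold higher number from compound 3 to compound 4 (0.09 log units; within the scatter), which is nothing beyond the scatter. Compound 4 is estimated at 35000 nM, with a range from 12000 nM to 100000 nM in this assay.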

Compound 4, concentration for 50% growth inhibition: 9150 nM
The estimate for compound 4 lay 3.8-fold (0.58 log units) above the measured number, and the stated range ends above it.
By their numbers in this assay, from the lowest: compound 4; then compounds 2, 3 and 1 (each within the scatter of the next).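

In this assay, among these compounds, going from 3-hydroxyphenyl to 3-methylphenyl gives a 3.1-fold lower number from compound 3 to compound 4 (0.49 log units; beyond the scatter), so this aromatic carbon is a place where exchanging one heavy atom for another can move the number beyond the scatter, something no earlier pair could show. The hydroxy, with its hydrogen-bond donor and acceptor, is therefore not required for growth inhibition on this scaffold, and here a methyl, which counts neither, goes with stronger inhibition, though this rests on a single pair of compounds. No measurement at hand bears on why the number moved.

Going by these compounds, it remains open whether the step comes from losing the hydroxy, from gaining the methyl, or from both, and an otherwise identical compound with plain hydrogen, a methoxy or an amine on this carbon would help to tell these readings apart. Also open, on these data alone, are how far the trend runs with a longer chain such as ethyl or propyl, and whether the same exchange would do the same on the core of compound 1.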